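A few compounds are considered here, and "the series" means these few. Any claim that something is new, unique, unknown or untested is made for them only; others in the source may bear on it.

Measured so far:
Compound 1, `COc1cc2ncnc(NNC(=S)NC(=O)c3cccc(Cl)c3)c2cc1OC`: 4830 nM
Compound 2, `O=C(NC(=S)NNc1ncnc2ccccc12)c1ccc(F)cc1`: 1870 nM
Compound 3, `O=C(NC(=S)NNc1ncnc2ccccc12)c1ccccc1Cl`: 7710 nM

All three were tested in a functional assay on KB cells (Homo sapiens) for cytotoxicity, read by MTT assay, with a stated time of 72 h; a higher number here means a weaker inhibitor, a lower number a stronger inhibitor. Among these numbers compound 1 stands second highest. Compound 3 lies within the scatter of compound 1, so nothing can be said about their order. Compound 2 gives a lower number than compound 1, and that gap lies beyond the scatter.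

Compound 4, `COc1cc2ncnc(NNC(=S)NC(=O)c3ccccc3OC)c2cc1OC`, has not yet been measured. It differs from compound 1 in one place: 2-methoxyphenyl in place of 3-chlorophenyl on a carbonyl carbon.

Going by the values given here, only one measured step touches the same place. Going from compound 2 to compound 3 swaps one ring on that carbonyl carbon for another, and it gives a 4.1-fold higher number from compound 2 to compound 3 (0.62 log units; beyond the scatter). Among the compounds with values here, that step concerns different rings on a different core, so it shows only that a swap at this position can move the number beyond the scatter, without telling the direction for a 2-methoxyphenyl. Within the data shown here, no measured compound carries a 2-methoxyphenyl. The expectation is therefore a number close to compound 1, with wide uncertainty in either direction.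

Compound 4 is expected to give about 5000 nM, within a range from 1500 nM to 16000 nM. This estimate amounts to an expected step of a 1.0-fold higher number from compound 1 to compound 4 (0.02 log units; within the scatter).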

Compound 4, half-maximal inhibitory concentration: 3850 nM
Compound 4: the middle estimate sits 1.3-fold (0.11 log units) above what was measured; low and high end bracket the measured number.
By their numbers in this assay, from the lowest: compound 2; then compounds 4, 1 and 3 (each within the scatter of the next).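

On the core shared by the two dimethoxy-bearing compounds, putting 2-methoxyphenyl in place of 3-chlorophenyl on the carbonyl carbon gives, in this assay, a 1.3-fold lower number from compound 1 to compound 4 (0.10 log units; within the scatter), so this exchange cannot be told apart from repeat-measurement noise. Going by these compounds alone, the only earlier step at this position, a 4.1-fold higher number from compound 2 to compound 3 (0.62 log units; beyond the scatter), showed on a different core that a ring swap here can matter, whereas the new step shows that a swap here need not move the number, even though a chlorine-bearing ring gives way to a methoxy-bearing one with 1 hydrogen-bond acceptor in place of 0. No separate measurement on these compounds bears on this outcome.

The compounds shown leave open whether 3-chlorophenyl and 2-methoxyphenyl would also sit within the scatter of each other on the core of compound 2, since a step seen on one core need not carry over to another. They also leave open what would happen at this carbonyl carbon with a ring carrying an amine or a carboxylic acid, or with a butyl chain in place of the ring.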